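A few compounds are considered here, and "the series" means these few. Any claim that something is new, unique, unknown or untested is made for them only; others in the source may bear on it.

Series notes. Compound 1 `O=c1c(Cc2coc3cccc(OCC4CCCCC4)c3c2=O)coc2ccccc12` is tested in a functional assay on ACHN cells (Homo sapiens) for antiproliferative activity, read by XTT assay (on this read-out lower numbers stand for stronger inhibition and higher numbers for weaker inhibition), where compound 1 gives 4230 nM. Of the two numbers in hand compound 1 holds the higher one; the nearest is compound 3 `O=c1c(Cc2coc3cccc(OCC4CCCCC4)c3c2=O)coc2cc(O)ccc12`, which in this assay gives 2100 nM, and the step of a 2.0-fold lower number from compound 1 to compound 3 (0.30 log units; within the scatter) stays within the scatter. Compound 2 `O=c1c(Cc2coc3cccc(OCC4CCCCC4)c3c2=O)coc2cc(Cl)ccc12` carries chloro in place of hydrogen on an aromatic carbon. In this assay compound 2 gives > 10000 nM, which is a limit of the assay and not a number. The step of an at least 2.3-fold higher number from compound 1 to compound 2 (0.37 log units; beyond the scatter) and the step of an at least 4.7-fold lower number from compound 2 to compound 3 (0.67 log units; beyond the scatter) both rest on that limit (the limit of > 10000 nM in this assay, at which 1 of the 3 values shown sits).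

Compound 4 `O=c1c(Cc2coc3ccccc3c2=O)coc2ccccc12` is not yet measured. It differs from compound 1 by hydrogen in place of cyclohexylmethoxy on an aromatic carbon. Within the data shown here, none of the measured steps touches this group: the three steps in hand all vary the other aromatic carbon and all keep the cyclohexylmethoxy. So no measured step bears on this change, and its size in this assay cannot be read from the compounds shown; it is a larger structural change than any measured step. Compound 4 is estimated at 7000 nM, with a range from 2500 nM to 20000 nM. The expected step of a 1.7-fold higher number from compound 1 to compound 4 (0.22 log units; within the scatter) is a guess toward a weaker number, with a fair chance that only a limit is reported.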

Compound 4, half-maximal inhibitory concentration: 510 nM
Compound 4: the middle estimate sits 14-fold (1.14 log units) above what was measured; the measured number lies below the stated range.
By their numbers in this assay, from the lowest: compound 4; then compounds 3 and 1 (each within the scatter of the next). At a limit, above all of these: compound 2.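

In this assay, among these compounds, the replacement of cyclohexylmethoxy by hydrogen gives an 8.3-fold lower number from compound 1 to compound 4 (0.92 log units; beyond the scatter) and is the first measured change at this position on the aromatic carbon, since all earlier steps kept that group in place and varied another aromatic carbon. In this pair, the cyclohexylmethoxy group is not required for a measurable value in this read-out, and its presence goes with the higher number. Nothing measured in the series accounts for the size of this step.

From the compounds shown here alone, the position is known only from hydrogen and cyclohexylmethoxy, so it remains open where a methoxy, a shorter alkoxy chain or an amine at the same carbon would fall relative to compound 4 and compound 1. Going by these compounds, it is also open whether chloro or hydroxy on the other aromatic carbon would have the same effect on compound 4 as on compound 1, and the chloro comparison gives only a bound, as the value of compound 2 is a limit of the assay.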